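The source may report more compounds than this note shows. Statements on the series, on what has been measured and on what is new or still open speak of the compounds shown alone.

In an ADME assay on Raji cells (Homo sapiens) for cytotoxicity, read by CellTiter-Glo and resazurin assay, with a stated time of 72 h (a higher number here means that more compound is needed for the effect, a lower number that less compound is needed), compound 1 `CC(C)Oc1cccc(-c2ccc(C(=O)N(Cc3cccc(OCCCCCC(=O)O)c3)C(C)C)cc2)c1` gives only a limit, > 26000 nM. Compound 2 `COc1cc(F)cc(-c2ccc(C(=O)N(Cc3cccc(OCCCCCC(=O)O)c3)C(C)C)cc2)c1` likewise reaches only a limit in this assay, > 26000 nM. The step that the two limits leave unreadable from compound 1 to compound 2 accordingly cannot be read. Compound 3 `CCOC(=O)CCCCCOc1cccc(CN(C(=O)c2ccc(-c3ccc4ccccc4c3)cc2)C(C)C)c1` also stands at a limit in this assay, > 26000 nM, which is no number because of the limit of > 26000 nM in this assay, at which 3 of the 3 values shown sit.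

The change to compound 4 `CCOC(=O)CCCCCOc1cccc(CN(C(=O)c2ccc(-c3ccco3)cc2)C(C)C)c1` is furan-2-yl in place of naphthalen-2-yl on an aromatic carbon. No measured step bears on this change: the only step shown, between compound 1 and compound 2, is unreadable, and every value sits at the limit, so neither a direction nor a size can be drawn from them. Compound 4 is expected to remain at the limit, the estimate being 30000 nM with a range from 8000 nM to 100000 nM. The step this estimate means, a step that the limit leaves unreadable from compound 3 to compound 4, is expected to stay within the scatter.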

Compound 4, half-maximal effective concentration: > 26000 nM
Compound 4: a limit, no number; the forecaster's own chance of this, stated with the estimate: 85%; the middle value lies beyond the limit too.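

The step between compound 3 and compound 4 cannot be read, because both stand at a limit: the limit of > 26000 nM in this assay, at which 4 of the 4 values shown sit. The compounds shown leave open what number any of them would reach in this assay and how far any change would shift it.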